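This account rests on a few compounds, and the source may have more. Where it says the series, first, only, none or still open, it means among the compounds named here.

Three measured members of the series share one core, and all three come out flat in an ADME assay on PC-3 cells (Homo sapiens) for cytotoxicity, read by WST assay, tested at 100 uM; a lower number here means less inhibition, a higher number more inhibition at the concentration tested (going by the name of the read-out). Compound 1 `O=C(Nc1ccc(Cl)cn1)C1CCCN(C(=O)c2cc(C(F)(F)F)cc(C(F)(F)F)c2)C1` gives 0% in this assay. Compound 2 `COC(=O)c1cccc(C(=O)N2CCCC(C(=O)Nc3ccc(Cl)cc3)C2)c1` gives 0% in this assay, and compound 3 `O=C(Nc1cccc(Oc2ccccc2)c1)C1CCCN(C(=O)c2cccc(-c3ccco3)c2)C1` gives 0% in this assay. Compound 1 thus stands level with compound 2 and with compound 3 at the digits shown; neither gap reaches beyond the scatter, so no order among the three can be read from these numbers.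

The next compound, compound 4 `O=C(Nc1ccc(Cl)cc1)C1CCCN(C(=O)c2cc(C(F)(F)F)cc(C(F)(F)F)c2)C1`, has not yet been measured in this assay. It differs from compound 1 in one place: 4-chlorophenyl in place of 5-chloropyridin-2-yl on an amide-type nitrogen. Going by the values given here, no measured pair isolates this change, so the numbers give no direct guide to its effect on the read-out. Since every measured compound, whatever its amide-side substituent, sits at the floor of this assay, the expected step is no change at the digits printed from compound 1 to compound 4 (within the scatter), that is, none beyond the scatter. Compound 4 is accordingly expected to give 0% in this assay, within a range of -8% to 10%.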

Compound 4, a percentage reported as inhibition, at one concentration (the size of the read-out at that concentration, not a potency): 14%
Compound 4: middle estimate off by 14 percentage points, on the low side, and the stated range ends below it.
By their numbers in this assay, from the lowest: compounds 1, 2 and 3 (each within the scatter of the next); then compound 4.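

In this assay, going by these compounds alone, the substituent on the amide-type nitrogen is the first place where a change lifts the number off the floor, with 4-chlorophenyl in place of 5-chloropyridin-2-yl giving a number 14 percentage points higher from compound 1 to compound 4 (beyond the scatter). The two groups have the same count of heavy atoms and differ in the ring nitrogen and its single hydrogen-bond acceptor, so a one-atom exchange in this ring is enough to produce a modest step. The 4-chlorophenyl group does not fix the number by itself: compound 2, which also carries it, gives 0%, while compound 4 gives 14%.

Nothing at hand accounts for the step. From the compounds shown here alone, it remains open whether a methyl group in place of the chlorine, or an amine or carboxylic acid on this ring, would shift the number further.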